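Chloro Substitution on Two Anilide Cores

This account rests on a few compounds, and the source may have more. Where it says the series, first, only, none or still open, it means among the compounds named here.

Compound 1 `O=C(CCCCC(S)CCS)Nc1ccccc1` and compound 2 `O=C(CCCCC(S)CCS)Nc1ccccc1Cl` share one core. In a functional assay on HO8910 cells (Homo sapiens) for inhibition, read by MTT assay, with a stated time of 24 h, tested at 0.1 ug/mL (a higher number here means more inhibition of growth at the concentration tested, a lower number less inhibition of growth), compound 1 gives 7.37%, and compound 2 gives 6.11%. The change between them is chloro in place of hydrogen on an aromatic carbon, and it produced a number 1.3 percentage points lower from compound 1 to compound 2 (within the scatter). Compound 3 `O=C(CCCCC(CCSC(=O)c1ccccc1)SC(=O)c1ccccc1)Nc1ccccc1` carries a second core; the difference between the two cores is not broken down here. In this assay compound 3 gives 3.12%. Compound 4 `O=C(CCCCC(CCSC(=O)c1ccccc1)SC(=O)c1ccccc1)Nc1ccccc1Cl` has not been measured and differs from compound 3 by chloro in place of hydrogen on an aromatic carbon, the same change as that from compound 1 to compound 2. The step is expected to be small, a number 0.9 percentage points higher from compound 3 to compound 4 (within the scatter), because a number 1.3 percentage points lower from compound 1 to compound 2 (within the scatter) stayed within the scatter. Compound 4 is therefore estimated at 4%, with a range from 0% to 12%.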

Compound 4, percent growth inhibition at one concentration: "not active" (no number reported)
The entry for compound 4 holds no number; no gap can be computed for the estimate.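

Among the compounds shown here, compound 4 is recorded as "not active" with no number, so no step from compound 3 to compound 4 can be read. The compounds shown leave open what chloro in place of hydrogen does on the core of compound 3. Nothing available bears on this result.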